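Aryl Swaps on the Sulfonyl Sulfur of a Shared Core

The source may hold more compounds than are shown below. What is called first, only, known or untested is meant among the compounds shown, and "the series" means these compounds.

Compound 1, `COc1ccc(S(=O)(=O)N(C)c2ccc3[nH]c(-c4n[nH]c5ccccc45)cc3n2)cc1`, gives 24300 nM in a functional assay on A549 cells (Homo sapiens) for antiproliferative activity, read by MTT assay, with a stated time of 72 h; on this read-out higher numbers stand for weaker inhibition and lower numbers for stronger inhibition.
Compound 2, `COc1ccc(OC)c(S(=O)(=O)N(C)c2ccc3[nH]c(-c4n[nH]c5ccccc45)cc3n2)c1`, gives 19400 nM in this assay.
Compound 3, `CN(c1ccc2[nH]c(-c3n[nH]c4ccccc34)cc2n1)S(=O)(=O)c1cccc([N+](=O)[O-])c1`, gives 20100 nM in this assay.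

All three measured compounds keep the same core and differ only in the aryl group attached to the sulfonyl sulfur. Compound 3 has the second highest of the three numbers in this assay. Its nearest neighbour is compound 2, with a 1.0-fold higher number from compound 2 to compound 3 (0.02 log units; within the scatter); its furthest is compound 1, with a 1.2-fold lower number from compound 1 to compound 3 (0.08 log units; within the scatter). The remaining pair shows a 1.3-fold lower number from compound 1 to compound 2 (0.10 log units; within the scatter). None of these steps leaves the scatter, so the three compounds cannot be ordered against one another.

Compound 4, `CN(c1ccc2[nH]c(-c3n[nH]c4ccccc34)cc2n1)S(=O)(=O)c1ccc(OC(F)(F)F)cc1`, has not yet been measured. It differs from compound 3 in one place: 4-(trifluoromethoxy)phenyl in place of 3-nitrophenyl on a sulfonyl sulfur.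

Within the data shown here, the steps that bear on this change are those that also exchanged the aryl group on the sulfonyl sulfur, namely a 1.2-fold lower number from compound 1 to compound 3 (0.08 log units; within the scatter) and a 1.0-fold higher number from compound 2 to compound 3 (0.02 log units; within the scatter), both within the scatter. On that basis no step beyond the scatter is expected in this assay for compound 4, and the step from compound 3 is estimated as a 1.0-fold lower number from compound 3 to compound 4 (0.00 log units; within the scatter). Compound 4 is therefore expected to give about 20000 nM, within a range from 8000 nM to 50000 nM.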

Compound 4, half-maximal inhibitory concentration: 8000 nM
Estimate against measurement, compound 4: 2.5-fold (0.40 log units) above, and the stated range covers the measured number.
By their numbers in this assay, from the lowest: compound 4; then compounds 2, 3 and 1 (each within the scatter of the next).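

Among these compounds, compound 4 is the first of the aryl groups on the sulfonyl sulfur to move the number beyond the scatter in this assay, with a 2.5-fold lower number from compound 3 to compound 4 (0.40 log units; beyond the scatter) and a 2.4-fold lower number from compound 2 to compound 4 (0.38 log units; beyond the scatter) as modest steps that set it apart from both groups that had looked interchangeable. The clearest reading comes from the smallest structural change, trifluoromethyl in place of methyl on an oxygen on an aromatic ring, which gives a 3.0-fold lower number from compound 1 to compound 4 (0.48 log units; beyond the scatter) and shows that this position can respond to a single substitution on the aryl group, even though the earlier swaps gave no step beyond the scatter. Nothing shown here offers an explanation for this modest shift.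

The compounds shown leave open whether the step depends on the oxygen link, since a trifluoromethyl group bonded directly to the phenyl ring does not appear among them. They also leave open whether a chlorine atom, an amine or a carboxylic acid on that ring, or a saturated chain in place of the aryl group on the sulfonyl sulfur, would lower the number further or return it to the level of the other three compounds.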